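The source may report more compounds than this note shows. Statements on the series, on what has been measured and on what is new or still open speak of the compounds shown alone.

In an assay on HeLa cells for inhibition of Indoleamine 2,3-dioxygenase 1 (Homo sapiens), with stated times of 1 h and 18 h (a lower number here means a stronger inhibitor, a higher number a weaker inhibitor), the two measured compounds give:

Compound 1, `Cc1ccc(NC(=O)Nc2cc(-c3ccccc3C(=O)O)ccc2N(C)C2CCCCC2)cc1`: 14 nM
Compound 2, `Cc1ccc(NC(=O)Nc2cc(-c3ccccc3C(=O)O)ccc2N(CC(C)C)C(C)C)cc1`: 42 nM

Going by the values given here, of these two numbers compound 2 has the higher one, and the only measured step, a 3.0-fold higher number from compound 1 to compound 2 (0.48 log units; beyond the scatter), lies beyond the scatter. Compound 3, `Cc1ccc(NC(=O)Nc2cc(-c3ccccc3C(=O)O)ccc2N(CC(C)C)CC(C)C)cc1`, has not yet been measured. It differs from compound 2 by isobutyl in place of isopropyl on a nitrogen on an aromatic ring. Among the compounds with values here, no measured pair shows this particular exchange, and the one step on record, a 3.0-fold higher number from compound 1 to compound 2 (0.48 log units; beyond the scatter), changed both groups on that nitrogen at once, so it gives only a loose guide. The exchange of an isopropyl for an isobutyl is small, and the expectation is a step of no more than the scatter, a 1.2-fold higher number from compound 2 to compound 3 (0.08 log units; within the scatter), in this assay. Compound 3 is therefore estimated at 50 nM, with a plausible range from 20 nM to 130 nM.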

Compound 3, half-maximal inhibitory concentration: 13 nM
Compound 3: the middle estimate sits 3.8-fold (0.59 log units) above what was measured; the measured number lies below the stated range.
By their numbers in this assay, from the lowest: compounds 3 and 1 (each within the scatter of the next); then compound 2.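

Isobutyl in place of isopropyl on the nitrogen gives a 3.2-fold lower number from compound 2 to compound 3 (0.51 log units; beyond the scatter) in this assay and, with one group changed alone for the first time, shows that a small exchange at this position can move the number beyond the scatter. Diisobutylamino in place of cyclohexyl(methyl)amino gives a 1.1-fold lower number from compound 1 to compound 3 (0.03 log units; within the scatter) and so shows that two open chains on this nitrogen and a cyclohexyl ring paired with a methyl cannot be told apart here. Nothing on hand explains why the isopropyl group in compound 2 goes with the higher number.

On these data alone, whether a longer chain such as hexyl on this nitrogen would hold the number at this level remains open. So does the effect of a chain carrying an ether oxygen or an amine at the same place.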